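A few compounds are considered here, and "the series" means these few. Any claim that something is new, unique, unknown or untested is made for them only; others in the source may bear on it.

Of the compounds shown here, three have been measured in a physicochemical assay for lipophilicity; on this read-out lower numbers stand for lower lipophilicity and higher numbers for higher lipophilicity. Compound 1, with the structure `Fc1cccc(F)c1C1=NC(c2ccccc2)CO1`, gives 3.01 in this assay. Compound 2, with the structure `O=[N+]([O-])c1ccccc1-c1ncco1`, gives 1.27 in this assay. Compound 3, with the structure `CCSc1ccccc1C1=NC(c2ccccc2)CO1`, gives 4.04 in this assay, the highest of the three numbers. Its gap to compound 1 and its gap to compound 2 both lie beyond the usual scatter of such measurements. Compound 3 stands clearly above the other two.

Compound 4, with the structure `CCOc1ccccc1C1=NC(c2ccccc2)CO1`, has not yet been measured in this assay. It differs from compound 3 in a single place: ethoxy in place of ethylsulfanyl on an aromatic carbon. Going by the values given here, no measured pair in this set shows a change of this kind, so the size of the step has to be guessed. A move downward of moderate size, beyond the scatter, is expected, so that the step from compound 3 to compound 4 in this assay is estimated at a number 0.64 log units lower from compound 3 to compound 4 (beyond the scatter). On that basis compound 4 is expected to give about 3.4 in this assay, most likely between 3 and 3.8.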

Compound 4, partition coefficient: 4.22
For compound 4 the middle estimate is 0.82 log units below the measured one; the measured number lies above the stated range.
By their numbers in this assay, from the lowest: compound 2; then compound 1; then compounds 3 and 4 (each within the scatter of the next).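

Going by these compounds alone, compound 3 and compound 4 form the first pair here that differs in one place, so a single change can now be read directly: with ethoxy in place of ethylsulfanyl on an aromatic carbon, ortho to a large group, this assay gives a step of a number 0.18 log units higher from compound 3 to compound 4 (within the scatter), and the two compounds cannot be told apart on this read-out. At this position and on this core, then, exchanging the sulfur of the chain for oxygen leaves the number within the ordinary spread of repeat measurements. Nothing at hand explains why the exchange leaves so little trace.

As far as these compounds go, whether an amine, a carboxylic acid or a longer chain such as propoxy at the same position would also stay within the scatter of compound 3 remains open. So does whether the same exchange would give so small a step elsewhere on the core.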